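This account rests on a few compounds, and the source may have more. Where it says the series, first, only, none or still open, it means among the compounds named here.

Compound 1 `Clc1sccc1-c1cc(-c2cnn(C3CCNCC3)c2)on1` gives 42% in an assay on a protein complex for positive allosteric modulation of Neuronal acetylcholine receptor; alpha4/beta2 (Homo sapiens); on this read-out lower numbers stand for smaller maximal responses and higher numbers for larger maximal responses.
Compound 2 `Clc1cccc(Cl)c1-c1cc(-c2cnn(C3CCNCC3)c2)on1` gives 73%.

Compound 2 stands highest of the two measured numbers; its nearest neighbour is compound 1, and the step of a number 31 percentage points higher from compound 1 to compound 2 (beyond the scatter) lies beyond the scatter. Compound 3 `Cc1cc(-c2cnn(C3CCNCC3)c2)on1` is not yet measured. It differs from compound 2 by methyl in place of 2,6-dichlorophenyl on an aromatic carbon. Among the compounds with values here, the only measured step, a number 31 percentage points higher from compound 1 to compound 2 (beyond the scatter), exchanges one aromatic group for another and does not match the loss of the whole aryl group, so it bears only loosely on the present step. Because the large step of a number 31 percentage points higher from compound 1 to compound 2 (beyond the scatter) shows the response moving strongly with the group at this position, a sizeable decrease is expected as a number 43 percentage points lower from compound 2 to compound 3 (beyond the scatter). Compound 3 is therefore estimated at 30%, within 5% to 65%.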

Compound 3, largest response reached (reported as efficacy), in percent of the reference or control that the assay uses: 19%
Compound 3: middle estimate off by 11 percentage points, on the high side, within the range that was stated.
By their numbers in this assay, from the lowest: compound 3; then compound 1; then compound 2.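

In this assay, methyl in place of 2,6-dichlorophenyl gives a number 54 percentage points lower from compound 2 to compound 3 (beyond the scatter), and methyl in place of 2-chlorothiophen-3-yl gives a number 23 percentage points lower from compound 1 to compound 3 (beyond the scatter). Both aromatic groups therefore stand above methyl, so the response at this carbon is not set by the shared core alone, and the size of the response follows which aromatic group is present. Nothing measured here accounts for these differences. The compounds shown leave open where an unsubstituted phenyl, a cyclohexyl group or a longer alkyl chain on this carbon would fall.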